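Antiproliferative series: alpha-methyl at the aryloxyacetic acid

The source may hold more compounds than are shown below. What is called first, only, known or untested is meant among the compounds shown, and "the series" means these compounds.

Measured compounds:
compound 1 `C=C(CCCC)C(=O)c1ccc(OC(C)C(=O)O)c(C)c1C`, 12100 nM
compound 2 `C=C(CCC)C(=O)c1ccc(OC(C)C(=O)O)c(C)c1C`, 11200 nM
compound 3 `C=C(CC)C(=O)c1ccc(OCC(=O)O)cc1Cl`, > 60000 nM

In a functional assay on HL-60 cells (Homo sapiens) for antiproliferative activity, with a stated time of 72 h (a higher number here means a weaker inhibitor of growth, a lower number a stronger inhibitor of growth), compound 1 gives 12100 nM and compound 2 gives 11200 nM. The difference between them is methyl in place of hydrogen on a saturated chain carbon, three bonds along the chain from a double-bonded chain carbon; it made a 1.1-fold higher number from compound 2 to compound 1 (0.03 log units; within the scatter). For compound 3 this assay gives only a limit, > 60000 nM, at which it sits together with no other compound shown (the limit of > 60000 nM in this assay, at which 1 of the 3 values shown sits). The difference between the core of compound 3 and the core of compound 2 is not broken down here.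

Compound 4 `C=C(CC)C(=O)c1ccc(OC(C)C(=O)O)cc1Cl` is not yet measured. It differs from compound 3 by methyl in place of hydrogen on a saturated chain carbon bound to a carbonyl carbon and an oxygen on an aromatic ring. This is the same kind of change as that from compound 2 to compound 1, not the same: there the methyl enters on a saturated chain carbon three bonds along the chain from a double-bonded chain carbon, here on a saturated chain carbon bound to a carbonyl carbon and an oxygen on an aromatic ring. Since compound 3 gives only the limit > 60000 nM, a small step is expected, a step that the limit leaves unreadable from compound 3 to compound 4, and compound 4 is expected near 70000 nM, between 25000 nM and 200000 nM, with a fair chance that this assay again reports only a limit.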

Compound 4, concentration for 50% growth inhibition: > 60000 nM
Compound 4 gave a limit, no number; the forecaster's own chance of this, stated with the estimate: 60%; the middle value is on the limit's open side.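

Compound 3 and compound 4 both give only a limit, so no step between them can be read: the limit of > 60000 nM in this assay, at which 2 of the 4 values shown sit.

Left open is whether carboxymethoxy and 1-carboxyethoxy differ at all on this core, as neither compound has a measured number.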